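Carbamate chain changes on a shared core

A few compounds are considered here, and "the series" means these few. Any claim that something is new, unique, unknown or untested is made for them only; others in the source may bear on it.

Compound 1 `CC(C)COC(=O)N1CCN(C(=O)c2nc(Nc3cc(C4CC4)[nH]n3)c3cc(Cl)ccc3n2)C[C@H]1C` gives 46.9%.
Compound 2 `CC(C)C(=O)OCOC(=O)N1CCN(C(=O)c2nc(Nc3cc(C4CC4)[nH]n3)c3cc(Cl)ccc3n2)C[C@H]1C` gives 86.9%.
Compound 3 `C[C@@H]1CN(C(=O)c2nc(Nc3cc(C4CC4)[nH]n3)c3cc(Cl)ccc3n2)CCN1C(=O)OCC(Cl)(Cl)Cl` gives 82.8%.

All three were measured in an assay for inhibition of serine/threonine-protein kinase PAK 4 (Homo sapiens), read by FRET and Z'-LYTE, with a stated time of 60 min, tested at 50 uM, in the presence of a further agent that is not named here; on this read-out higher numbers stand for a stronger effect at the one concentration tested and lower numbers for a weaker effect. Compound 3 stands second highest of the three; compound 2 is its nearest neighbour, within the scatter, while compound 1 lies furthest away and below it, beyond the scatter. Compound 4 `C[C@@H]1CN(C(=O)c2nc(Nc3cc(C4CC4)[nH]n3)c3cc(Cl)ccc3n2)CCN1C(=O)OCOC(=O)C(C)(C)C` differs from compound 3 in one place: ((tert-butyl)carbonyl)oxy in place of trichloromethyl on a saturated chain carbon bound to an oxygen next to a carbonyl group. Among the compounds with values here, two measured steps bear on this. a number 40 percentage points higher from compound 1 to compound 2 (beyond the scatter) shows a large rise when (isopropylcarbonyl)oxy replaces isopropyl at that saturated chain carbon. a number 4.1 percentage points lower from compound 2 to compound 3 (within the scatter) shows that (isopropylcarbonyl)oxy and trichloromethyl at the same place sit within the scatter of each other. Compound 4 makes the reverse kind of swap, with ((tert-butyl)carbonyl)oxy, so a step within the scatter is expected: a number 2.2 percentage points higher from compound 3 to compound 4 (within the scatter). For compound 4 the estimate is 85%, expected between 70% and 97%.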

Compound 4, a percentage reported as inhibition, at one concentration (the size of the read-out at that concentration, not a potency) in the serine/threonine-protein kinase PAK 4 assay: 60.5%
For compound 4 the middle estimate is 24.5 percentage points above the measured one; measured number below the stated range.
By their numbers in the serine/threonine-protein kinase PAK 4 assay, from the lowest: compound 1; then compound 4; then compounds 3 and 2 (each within the scatter of the next).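

In the serine/threonine-protein kinase PAK 4 assay compound 4 gives 60.5% and ((tert-butyl)carbonyl)oxy in place of trichloromethyl gives a number 22.3 percentage points lower from compound 3 to compound 4 (beyond the scatter) and so breaks the match seen between trichloromethyl and (isopropylcarbonyl)oxy. Methyl in place of hydrogen on a saturated chain carbon bound to a carbonyl carbon and two saturated chain carbons is enough for a number 26.4 percentage points lower from compound 2 to compound 4 (beyond the scatter) and the gain over isopropyl narrows to a number 13.6 percentage points higher from compound 1 to compound 4 (beyond the scatter) at this place. In a physicochemical assay, read by HPLC, in phosphate buffer, with a stated time of 2 h, at pH 7.4 (on this read-out higher numbers stand for a more stable compound and lower numbers for a less stable compound), compound 3 gives 98.7% and compound 4 gives 97.7% and the same swap gives a number 1 percentage points lower from compound 3 to compound 4 (within the scatter) and so does not separate the two compounds on that read-out.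

From the compounds shown here alone, whether an amine or a carboxylic acid at this chain carbon would hold the higher numbers stays open. No measured evidence accounts for these steps.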